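One more chloro on compound 1

The source may hold more compounds than are shown below. What is called first, only, known or untested is meant among the compounds shown, and "the series" means these compounds.

- compound 1 `O=C(Nc1ccc(Cl)cc1)N1CCN(c2ccc3nncn3n2)CC1` gives 200000 nM as measured
- compound 2 `O=C(Nc1ccc(Cl)c(Cl)c1)N1CC=C(c2ccc3nncn3n2)CC1` gives 59000 nM as measured

In a physicochemical assay for solubility, measured as kinetic solubility, at pH 7.4 (on this read-out lower numbers stand for lower solubility and higher numbers for higher solubility), compound 1 stands highest of the two, and the number for compound 2 is lower by more than the scatter. Compound 3 `O=C(Nc1ccc(Cl)c(Cl)c1)N1CCN(c2ccc3nncn3n2)CC1` has chloro in place of hydrogen on an aromatic carbon so 4-chlorophenyl becomes 3,4-dichlorophenyl. Among the compounds with values here, no measured pair shows this change alone. Compound 2 also carries 3,4-dichlorophenyl and gives 59000 nM as its value, so a lower number is expected in this assay here. The expected size is a 5.0-fold lower number from compound 1 to compound 3 (0.70 log units; beyond the scatter) which would lie beyond the scatter. For compound 3 the estimated value is 40000 nM with an expected range from 10000 nM to 130000 nM in this measurement.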

Compound 3, solubility: 1800 nM
For compound 3 the middle estimate is 22-fold (1.35 log units) above the measured one; measured number below the stated range.
By their numbers in this assay, from the lowest: compound 3; then compound 2; then compound 1.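

In this assay, a single chloro in place of hydrogen on an aromatic carbon, turning 4-chlorophenyl into 3,4-dichlorophenyl, gives a 110-fold lower number from compound 1 to compound 3 (2.05 log units; beyond the scatter) as a large step. The same 3,4-dichlorophenyl group does not fix the number: compound 2 gives 59000 nM while compound 3 gives 1800 nM in this read-out. No measurement shown here accounts for the size of this step.

From the compounds shown here alone, whether only chloro does this at this place stays open, since fluoro, methyl or methoxy there could give a smaller or larger step. Also open, going by these compounds, is whether an amine on the same ring would bring the number back up.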